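Aryl swap on the shared core: compound 3 to compound 4

This account rests on a few compounds, and the source may have more. Where it says the series, first, only, none or still open, it means among the compounds named here.

Measured so far:
- compound 1 `Cn1cc(/C=C2/C(=O)Nc3ccccc32)c2cc(Nc3nccc(-c4ccccc4)n3)ccc21`: 42900 nM
- compound 2 `COc1ccc(-c2ccnc(Nc3ccc4c(c3)c(/C=C3/C(=O)Nc5ccccc53)cn4C)n2)cc1`: limit, see below
- compound 3 `Cn1cc(/C=C2/C(=O)Nc3ccccc32)c2cc(Nc3nccc(-c4ccc(Cl)cc4)n3)ccc21`: 23500 nM

In a functional assay on MCF7 cells (Homo sapiens) for cytotoxicity, read by MTT assay, with a stated time of 48 h (on this read-out higher numbers stand for weaker inhibition and lower numbers for stronger inhibition), compound 3 gives the lowest of the two numbers shown, but its nearest neighbour is compound 1, and that gap, a 1.8-fold lower number from compound 1 to compound 3 (0.26 log units; within the scatter), sits within the scatter, so no order between them is claimed. Compound 2 reaches only a limit, > 100000 nM, at the edge of this assay (the limit of > 100000 nM in this assay, at which 1 of the 3 values shown sits). The steps of an at least 2.3-fold higher number from compound 1 to compound 2 (0.36 log units; beyond the scatter) and an at least 4.2-fold lower number from compound 2 to compound 3 (0.62 log units; beyond the scatter) are the only ones beyond the scatter.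

Compound 4 `Cn1cc(/C=C2/C(=O)Nc3ccccc32)c2cc(Nc3nccc(-c4cccnc4)n3)ccc21` differs from compound 3 by pyridin-3-yl in place of 4-chlorophenyl on an aromatic carbon. Going by the values given here, no measured step covers this change; the measured steps at the same place span a modest range around the values of compound 1 and compound 3. A step within the scatter, or a modest rise, is therefore expected, a 1.5-fold higher number from compound 3 to compound 4 (0.17 log units; within the scatter). Compound 4 is estimated at 35000 nM, between 12000 nM and 100000 nM.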

Compound 4, half-maximal inhibitory concentration: 46600 nM
The estimate for compound 4 lay 1.3-fold (0.12 log units) below the measured number, within the range that was stated.
By their numbers in this assay, from the lowest: compounds 3, 1 and 4 (each within the scatter of the next). At a limit, above all of these: compound 2.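

In this assay, going by these compounds alone, pyridin-3-yl, the only group here whose ring holds a hetero atom, cannot be told apart from the carbon-only rings 4-chlorophenyl and phenyl at this position: a 2.0-fold higher number from compound 3 to compound 4 (0.30 log units; within the scatter) and a 1.1-fold higher number from compound 1 to compound 4 (0.04 log units; within the scatter). Within the data shown here, only the step from the 4-methoxyphenyl compound clears the scatter, with an at least 2.1-fold lower number from compound 2 to compound 4 (0.33 log units; beyond the scatter). The number for compound 2 is a limit: the limit of > 100000 nM in this assay, at which 1 of the 4 values shown sits.

On these data alone, whether an amine or a carboxylic acid on this aryl ring would move the number beyond the scatter stays open.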